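Tert-butyl in place of methoxycarbonyl on compound 2

A few compounds are considered here, and "the series" means these few. Any claim that something is new, unique, unknown or untested is made for them only; others in the source may bear on it.

Of the compounds shown here, three have values so far in a physicochemical assay for lipophilicity, measured as octanol-water partition; on this read-out higher numbers stand for higher lipophilicity and lower numbers for lower lipophilicity. Compound 1 (`O=C(C[C@H]1CC(=O)c2c(F)cc(F)cc21)N[C@@H]1O[C@H](CO)[C@@H](O)[C@H](O)[C@H]1O`) gives -1.21, compound 2 (`COC(=O)c1ccc(/C=C/C(=O)N[C@@H]2O[C@H](CO)[C@@H](O)[C@H](O)[C@H]2O)cc1`) gives -0.805 and compound 3 (`C[C@H](CC(=O)N[C@@H]1O[C@H](CO)[C@@H](O)[C@H](O)[C@H]1O)c1ccc(C(C)(C)C)cc1`) gives 0.33. Compound 2 is thus the second highest of the three, above compound 1 and below compound 3, with both gaps beyond the scatter.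

Compound 4 (`CC(C)(C)c1ccc(/C=C/C(=O)N[C@@H]2O[C@H](CO)[C@@H](O)[C@H](O)[C@H]2O)cc1`) still awaits measurement. The structural change from compound 2 is tert-butyl in place of methoxycarbonyl on an aromatic carbon. For the measured compounds named here, no measured pair isolates this change, so the expectation rests on thin evidence. Compound 3 also carries tert-butyl on an aromatic carbon and gives 0.33, although the rest of its structure differs from that of compound 4. An upward step beyond the scatter is expected in this assay, estimated as a number 1.21 log units higher from compound 2 to compound 4 (beyond the scatter). For compound 4 the estimated value is 0.4, with an expected range of -0.1 to 1.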

Compound 4, partition coefficient: 0.496
Compound 4: the middle estimate sits 0.10 log units below what was measured; the measured number falls inside the stated range.
By their numbers in this assay, from the lowest: compound 1; then compound 2; then compounds 3 and 4 (each within the scatter of the next).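

Tert-butyl in place of methoxycarbonyl on this aromatic carbon now has its first direct reading in this assay: a number 1.30 log units higher from compound 2 to compound 4 (beyond the scatter), a large step. Both groups have 4 heavy atoms, but 2 oxygen atoms and 2 hydrogen-bond acceptors leave with methoxycarbonyl, while the rest of the structure stays fixed, so the step belongs to this one position and this one exchange. No measurement at hand accounts for the size of the step.

A single pair cannot show whether the same exchange gives a similar step on another core, such as that of compound 1. The compounds shown also leave open where an amine, a carboxylic acid or a simple methyl group on this aromatic carbon would fall relative to tert-butyl and methoxycarbonyl.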